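Swapping methylsulfonyl for chloro on a receptor agonist

The source may report more compounds than this note shows. Statements on the series, on what has been measured and on what is new or still open speak of the compounds shown alone.

Measured so far:
- compound 1, `FC(F)(F)Oc1ccc(CNc2nc(NCC3CC3)cc(-c3ccccn3)n2)cc1`, 22 nM
- compound 2, `CNc1nc(NCc2ccc(S(C)(=O)=O)cc2)cc(-c2ccccn2)n1`, 185 nM
- compound 3, `c1ccc(-c2cc(NCC3CC3)ncn2)nc1`, 10000 nM

All three were tested in a functional assay on HEK293 cells for agonist activity at G-protein coupled receptor 39 (Mus musculus), read by inositol phosphate accumulation; on this read-out higher numbers stand for an effect only at larger amounts of compound and lower numbers for an effect already at smaller amounts. Compound 1 gives 22 nM, compound 2 gives 185 nM and compound 3 gives 10000 nM. Compound 2 therefore stands second of the three: compound 1 sits well below it, beyond the scatter, and compound 3 sits far above it, also beyond the scatter. Compound 2 differs from both neighbours in more than one place, so no single change can be read off from those pairs.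

The next compound, compound 4, `CNc1nc(NCc2ccc(Cl)cc2)cc(-c2ccccn2)n1`, keeps the shared core and the methylamino group of compound 2 and alters only the benzyl ring: chloro in place of methylsulfonyl on an aromatic carbon.

Among the compounds with values here, no measured pair isolates this change, so the expectation rests on compound 2 alone. A modest shift toward a lower number is expected, the step from compound 2 to compound 4 being estimated as a 2.6-fold lower number from compound 2 to compound 4 (0.42 log units; beyond the scatter), within or just beyond the scatter. Compound 4 is estimated at 70 nM, in the range 20 nM to 250 nM.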

Compound 4, half-maximal effective concentration: 3 nM
Beside the measured number, compound 4's estimate is 23-fold (1.37 log units) above it; the whole stated range lies above it.
By their numbers in this assay, from the lowest: compound 4; then compound 1; then compound 2; then compound 3.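

In this assay, within the data shown here, compounds 2 and 4 form the first pair here that differs in only one place, so the effect of a group on this aromatic carbon can be read directly: chloro in place of methylsulfonyl gives a 62-fold lower number from compound 2 to compound 4 (1.79 log units; beyond the scatter), a large step. The methylsulfonyl group, with its 4 heavy atoms and 2 hydrogen-bond acceptors, is therefore not required for an effect at small amounts of compound, since a single chlorine atom with no hydrogen-bond acceptors does better. Nothing available explains why this swap has so large an effect.

As far as these compounds go, only these two groups can be compared at this position, so it remains open how a fluoro, a methyl, a methoxy or an amine would behave there. From the compounds shown here alone, it is also open whether the same swap would give a step of similar size on a compound with a different amine on the core.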